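Adding a second chloro to compound 1's aryl ring

The compounds below may be only part of what the source reports. "The series", "measured", "known", "first", "only" and "open" are said of these compounds alone.

Measured so far:
compound 1, `CCCc1cc(N)c2cc(NC(=O)/C=C/c3ccc(Cl)cc3)ccc2n1`: 6 nM
compound 2, `CC(C)(C)c1cc(N)c2cc(NC(=O)/C=C/c3ccc(C(F)(F)F)cc3)ccc2n1`: 0.3 nM

Both compounds were tested in an assay on isolated protein for displacement of a labelled ligand from melanin-concentrating hormone receptor 1 (Homo sapiens); a lower number here means a stronger inhibitor, a higher number a weaker inhibitor. Of the two numbers, compound 1 stands highest; the nearest, compound 2, gives a clearly lower number, a gap well beyond the usual scatter. The unmeasured compound 3, `CCCc1cc(N)c2cc(NC(=O)/C=C/c3ccc(Cl)c(Cl)c3)ccc2n1`, is reached from compound 1 by one change: chloro in place of hydrogen on an aromatic carbon. Going by the values given here, no step between two measured compounds matches this change, so there is nothing measured to lean on directly. Still, the gap between compound 1 and compound 2 shows that the numbers in this series can move a good deal. A modest drop in the number is expected, with the step from compound 1 to compound 3 estimated at a 2.0-fold lower number from compound 1 to compound 3 (0.30 log units; within the scatter). For compound 3 the expected value is 3 nM, with a range from 0.8 nM to 12 nM.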

Compound 3, half-maximal inhibitory concentration: 60 nM
Estimate against measurement, compound 3: 20-fold (1.30 log units) below, and the stated range ends below it.
By their numbers in this assay, from the lowest: compound 2; then compound 1; then compound 3.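

In this assay, going from 4-chlorophenyl to 3,4-dichlorophenyl gives a 10-fold higher number from compound 1 to compound 3 (1.00 log units; beyond the scatter), so this aromatic carbon, ortho to the existing chloro group, does not accept a second chloro without cost. One added heavy atom, with no hydrogen-bond donors or acceptors and no net charge, is enough to weaken the inhibitor by a step beyond the usual scatter. Nothing measured here accounts for this loss.

On these data alone, whether fluoro, methyl or methoxy on this same aromatic carbon would raise the number as far as chloro does remains open. Also open is whether chloro on a different carbon of this aromatic ring would carry a similar cost, as this is the only such step shown.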